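Working notes: ring substitution and paw edema inhibition

The compounds below may be only part of what the source reports. "The series", "measured", "known", "first", "only" and "open" are said of these compounds alone.

Compound 1 `C/C(=N\OCC(=O)O)c1ccccc1`: in a functional assay on the whole organism for inhibition, with Rattus norvegicus as the target, read by paw edema, with stated times of 1 h and 3 h, at a dose of 50 mg/kg by the oral route (a lower number here means less inhibition, a higher number more inhibition at the dose given (going by the name of the read-out)), compound 1 gives < 20%, a limit of the assay, not a number.
Compound 2 `C/C(=N\OCC(=O)O)c1ccccc1C(=O)O`: in this assay compound 2 gives < 20%, likewise a limit.
Compound 3 `C/C(=N\OCC(=O)O)c1cccc(Cl)c1`: in this assay compound 3 gives 20%.

Compound 1 stands only at a limit in this assay; one further value is a limit as well, and the limit of < 20% in this assay, at which 2 of the 3 values shown sit, is where two of the three values sit. The step that the two limits leave unreadable from compound 1 to compound 2 cannot be read. The step of a number no lower from compound 1 to compound 3 (the limit leaves the size open) is no lower, its size open. Compound 4 `C/C(=N\OCC(=O)O)c1ccc(C)cc1` differs from compound 1 by methyl in place of hydrogen on an aromatic carbon. Neither measured step yields a readable size, and the chloro change reached only the level of the limit, so no step beyond the scatter is expected; the step that the limit leaves unreadable from compound 1 to compound 4 is estimated to be small. Compound 4 is expected to give 15% in this assay, within 5% to 30%.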

Compound 4, a percentage reported as inhibition, in the whole organism at one dose (the size of the read-out at that dose, not a potency): 20%
Compound 4: the middle estimate sits 5 percentage points below what was measured; the measured number falls inside the stated range.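

In this assay methyl on the aromatic carbon para to the group of 8 heavy atoms gives a number no lower from compound 1 to compound 4 (the limit leaves the size open) and shows that this position accepts a small carbon group with a reading that is a number. Compound 1 gives < 20% as a limit of the assay. None of the steps from compound 1 can be sized, so the effect of methyl here stays unquantified: the limit of < 20% in this assay, at which 2 of the 4 values shown sit.

From the compounds shown here alone, what an amine, a methoxy group or a longer alkyl chain would give at this same position remains open.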